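This account rests on a few compounds, and the source may have more. Where it says the series, first, only, none or still open, it means among the compounds named here.

Compound 2 `COc1cc(-c2cc(/C=C/C(=O)c3ccc(N)cc3)[nH]n2)cc(OC)c1OC` is assessed in a functional assay on Malme-3M cells (Homo sapiens) for inhibition, read by sulforhodamine B assay, with a stated time of 48 h; a higher number here means that more compound is tolerated, a lower number that less compound is tolerated. In this assay compound 2 gives 14400 nM, the second highest of the three numbers shown so far. Compound 1 `COc1ccc(-c2cc(/C=C/C(=O)c3ccc(N)cc3)[nH]n2)cc1` gives 28800 nM, a value that lies within the scatter of compound 2, while compound 3 `COc1ccc(C(=O)/C=C/c2cc(-c3cc(OC)c(OC)c(OC)c3)n[nH]2)cc1OC` gives 6790 nM. Going by the values given here, the one measured step between neighbours, a 2.1-fold lower number from compound 2 to compound 3 (0.33 log units; beyond the scatter), replaces the aminophenyl group on the carbonyl carbon.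

Compound 4 `COc1ccc(-c2cc(/C=C/C(=O)c3ccc(N)cc3)[nH]n2)cc1OC` differs from compound 2 in a single place: hydrogen in place of methoxy on an aromatic carbon. The carbonyl side of the molecule is untouched; one methoxy group simply leaves the aromatic ring on the other side. Among the compounds with values here, none of the measured steps bears on this change: the step from compound 2 to compound 3 alters a different group entirely. Compound 1 and compound 2 differ from each other in two places, and their values sit within the scatter of each other, so they give no direction either. With nothing to point one way or the other, no step beyond the scatter is expected in this assay, and the range must be kept wide. Compound 4 is therefore estimated at 17000 nM, between 7000 nM and 40000 nM, which corresponds to an expected step of a 1.2-fold higher number from compound 2 to compound 4 (0.07 log units; within the scatter).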

Compound 4, concentration lethal to 50% of the cells: 59200 nM
Compound 4: the middle estimate sits 3.5-fold (0.54 log units) below what was measured, outside the stated range (above it).
By their numbers in this assay, from the lowest: compound 3; then compounds 2 and 1 (each within the scatter of the next); then compound 4.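

In this assay the methoxy group that is ortho to a methoxy group and meta to a large group clearly counts: replacing it with hydrogen gives a 4.1-fold higher number from compound 2 to compound 4 (0.61 log units; beyond the scatter) and so more compound is tolerated without it. Putting a methoxy group onto the ring of compound 1 gives a 2.1-fold higher number from compound 1 to compound 4 (0.31 log units; beyond the scatter) and thus also raises the number, so compound 4 stands above both of its neighbours, and the number does not simply follow how many methoxy groups the ring carries. Nothing available here explains why the number rises from either side.

Still open, on these data alone, is whether another small group at this place, such as a hydroxyl, a fluorine atom or an amine, would give a number closer to that of compound 2 or to that of compound 4. Also open, as far as these compounds go, is whether hydrogen in place of this methoxy group would raise the number in the same way when the carbonyl carbon carries the 3,4-dimethoxyphenyl group of compound 3 instead of the 4-aminophenyl group.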